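The source may hold more compounds than are shown below. What is called first, only, known or untested is meant among the compounds shown, and "the series" means these compounds.

Measured compounds:
compound 1 `CCS[C@@H]1[C@H](SCC)[C@@H](Cn2cc(-c3ccc(F)cc3)nn2)O[C@H]1n1cc(C)c(=O)[nH]c1=O`: >= 100000 nM (a limit of the assay)
compound 2 `CCS[C@@H]1[C@H](SCC)[C@@H](Cn2cc(-c3ccc(OC)cc3)nn2)O[C@H]1n1cc(C)c(=O)[nH]c1=O`: 25900 nM

In a functional assay on LAC cells (Homo sapiens) for cytotoxicity, read by MTT assay, with a stated time of 72 h (a lower number here means that less compound is needed, a higher number that more compound is needed for the effect), compound 1 gives >= 100000 nM, which is a limit of the assay and not a number. In this assay compound 2 gives 25900 nM, the only number shown in the series. Compound 3 `CCS[C@@H]1[C@H](SCC)[C@@H](Cn2cc(-c3ccc(C)cc3)nn2)O[C@H]1n1cc(C)c(=O)[nH]c1=O` differs from compound 2 by methyl in place of methoxy on an aromatic carbon. Among the compounds with values here, the single measured step, an at least 3.8-fold lower number from compound 1 to compound 2 (0.58 log units; beyond the scatter), touches the same aromatic carbon and carried the number out of the limit at which compound 1 sits (the limit of >= 100000 nM in this assay, at which 1 of the 2 values shown sits). Within the data shown here, no measured step exchanges methoxy for methyl, so only a small shift, probably within the scatter, is expected in this assay. Compound 3 is estimated at 30000 nM, with a range from 12000 nM to 90000 nM. This expectation amounts to a 1.2-fold higher number from compound 2 to compound 3 (0.06 log units; within the scatter), a step not expected to exceed the scatter.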

Compound 3, half-maximal effective concentration: >= 100000 nM
Compound 3 ended at the assay's limit; the forecaster's own chance of this, stated with the estimate: 25%; at least 3.3-fold (0.52 log units) between middle value and limit.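

In this assay, the change from 4-methoxyphenyl to 4-methylphenyl gives an at least 3.8-fold higher number from compound 2 to compound 3 (0.58 log units; beyond the scatter), so the earlier result, an at least 3.8-fold lower number from compound 1 to compound 2 (0.58 log units; beyond the scatter), does not extend to every replacement of fluoro on this aromatic carbon. Of the three groups shown at this position, only methoxy gives a number; the step between compound 1 and compound 3 cannot be read, as both values are limits of the assay. Most of the series now rests at that limit: the limit of >= 100000 nM in this assay, at which 2 of the 3 values shown sit.

Going by these compounds, whether the number depends on the oxygen or on the methoxy group as a whole stays open, and a hydroxyl, an ethoxy or a dimethylamino group on the same carbon would bear on this. On these data alone, compound 2 gives 25900 nM, and how far any other group on this carbon could lower that number is also open.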